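Swapping a carboxy for bromo on the second core

This account rests on a few compounds, and the source may have more. Where it says the series, first, only, none or still open, it means among the compounds named here.

The study compares two cores, each carrying a nitro-substituted hydroxyphenyl group on a double-bonded chain carbon. Compound 1 `O=C(O)c1ccc(C(=O)/C(=C\c2ccc(O)c([N+](=O)[O-])c2)SCc2ccc(Br)cc2)cc1` is the parent of the first core, and in a functional assay on DU-145 cells (Homo sapiens) for inhibition, read by trypan blue exclusion, with a stated time of 96 h (on this read-out higher numbers stand for weaker inhibition of growth and lower numbers for stronger inhibition of growth), compound 1 gives 50000 nM. Compound 2 `O=C(/C(=C\c1ccc(O)c([N+](=O)[O-])c1)SCc1ccc(Br)cc1)c1ccc(Br)cc1` differs from it by one change, (bromo in place of carboxy on an aromatic carbon), and in this assay compound 2 gives 10000 nM; the step of a 5.0-fold lower number from compound 1 to compound 2 (0.70 log units; beyond the scatter) is the measured effect of that change. Compound 3 `O=C(O)c1ccc(C(=O)/C(=C\c2ccc([N+](=O)[O-])c(O)c2)SCc2ccc(Br)cc2)cc1` carries the second core: the difference between the two cores is 3-hydroxy-4-nitrophenyl in place of 4-hydroxy-3-nitrophenyl on a double-bonded chain carbon bound to a double-bonded chain carbon, and the step of a 5.0-fold lower number from compound 1 to compound 3 (0.70 log units; beyond the scatter) shows what the change of core did on its own. In this assay compound 3 gives 10000 nM, level with compound 2 at the digits recorded.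

Compound 4 `O=C(/C(=C\c1ccc([N+](=O)[O-])c(O)c1)SCc1ccc(Br)cc1)c1ccc(Br)cc1` has not yet been measured. Within the data shown here, it is related to compound 3 by bromo in place of carboxy on an aromatic carbon, the same change as the one made from compound 1 to compound 2, set at a place described in the same words. Among the measured compounds shown here, only one measured instance of the change exists, so the expectation rests on a single step. Compound 4 is expected to show a step of about a 4.0-fold lower number from compound 3 to compound 4 (0.60 log units; beyond the scatter), close to the earlier one, because compound 1 to compound 2 gave a 5.0-fold lower number from compound 1 to compound 2 (0.70 log units; beyond the scatter). Compound 4 is therefore estimated at 2500 nM, within a range of 800 nM to 8000 nM.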

Compound 4, concentration for 50% growth inhibition: 10000 nM
Estimate against measurement, compound 4: 4.0-fold (0.60 log units) below, outside the stated range (above it).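

In this assay, bromo in place of carboxy on the second core gives no change at the digits printed from compound 3 to compound 4 (within the scatter), and the exchange of 4-hydroxy-3-nitrophenyl for 3-hydroxy-4-nitrophenyl, made with bromo already in place, gives no change at the digits printed from compound 2 to compound 4 (within the scatter). The bromo step seen on the core of compound 1 therefore did not carry over to the second core, so in this pair of cores its size cannot be assumed to transfer: the same change on two cores in this assay, a 5.0-fold lower number (0.70 log units; beyond the scatter) from compound 1 to compound 2 and no change at the digits printed (within the scatter) from compound 3 to compound 4, 5.0-fold (0.70 log units) apart, beyond the scatter of two such steps The change of core behaves in the same way, since either change made alone lowers the number from that of compound 1 while both together bring nothing further, but four compounds with a single pair of steps per change do not show why this happens or whether it holds beyond them: the same change on two cores in this assay, a 5.0-fold lower number (0.70 log units; beyond the scatter) from compound 1 to compound 3 and no change at the digits printed (within the scatter) from compound 2 to compound 4, 5.0-fold (0.70 log units) apart, beyond the scatter of two such steps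

As far as these compounds go, whether other groups in place of the carboxy, such as an amine or a methyl ester, would also stop at the level shared by compound 2, compound 3 and compound 4 remains open. From the compounds shown here alone, it is also open whether that level would hold with a nitrile in place of the nitro group.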